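The source may hold more compounds than are shown below. What is called first, only, known or untested is meant among the compounds shown, and "the series" means these compounds.

Compound 1 `COc1cc(/C=C/C(=O)/C=C/c2cccc3ccccc23)ccc1OCc1cn(CCCCCOc2cc(=O)oc3ccccc23)nn1`: 44%
Compound 2 `COc1ccc(/C=C/C(=O)/C=C/c2ccc(OCc3cn(CCCCCOc4cc(=O)oc5ccccc45)nn3)c(OC)c2)cc1`: 39%
Compound 3 `COc1ccccc1/C=C/C(=O)/C=C/c1ccc(OCc2cn(CCCCCOc3cc(=O)oc4ccccc34)nn2)c(OC)c1`: 37%

All three were tested in a functional assay on THP-1 cells (Homo sapiens) for inhibition, read by sulforhodamine B assay, with a stated time of 48 h, tested at 50 uM; on this read-out lower numbers stand for less inhibition of growth and higher numbers for more inhibition of growth at the one concentration tested. There compound 3 gives 37% and cannot be told apart from the other two, as the steps show: a number 2 percentage points lower from compound 2 to compound 3 (within the scatter) and a number 7 percentage points lower from compound 1 to compound 3 (within the scatter). Compound 4 `COc1cc(/C=C/C(=O)/C=C/c2ccco2)ccc1OCc1cn(CCCCCOc2cc(=O)oc3ccccc23)nn1` carries one change relative to compound 3, furan-2-yl in place of 2-methoxyphenyl on a double-bonded chain carbon bound to a double-bonded chain carbon. The measured steps that bear on this change are the two above and a number 5 percentage points lower from compound 1 to compound 2 (within the scatter), since all three exchange the group at this same place. None of them involves furan-2-yl, so they offer only indirect guidance. Exchanges among naphthalen-1-yl, 4-methoxyphenyl and 2-methoxyphenyl stayed within the scatter, so no step beyond the scatter is expected in this assay, and no firm direction can be given. The step expected is a number 2 percentage points higher from compound 3 to compound 4 (within the scatter). Compound 4 is estimated at 39%, with an expected range of 27% to 51%.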

Compound 4, percent growth inhibition at one concentration: 39%
For compound 4 middle estimate and measured number coincide at the digits printed; the range from low to high includes it.
By their numbers in this assay, from the lowest: compounds 3, 2, 4 and 1 (each within the scatter of the next).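

In this assay, among these compounds, furan-2-yl, with its five-membered aromatic ring and 5 heavy atoms, is the first group at this place on a double-bonded chain carbon bound to a double-bonded chain carbon that is not a six-membered aromatic ring of carbon only or a naphthalen-1-yl group. The exchange leaves every step within the scatter (a number 2 percentage points higher from compound 3 to compound 4 (within the scatter)), (no change at the digits printed from compound 2 to compound 4 (within the scatter)) and (a number 5 percentage points lower from compound 1 to compound 4 (within the scatter)), so all four groups tried here fall within the scatter of one another. Nothing at hand explains this lack of separation.

As far as these compounds go, whether an aminomethyl or carboxylic acid group on the ring at this place, or a saturated cyclohexyl ring in place of it, would give a step beyond the scatter remains open. So does the effect of a longer chain elsewhere in the shared core.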